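Swapping the benzothiazole substituents on a cytotoxic amide

The compounds below may be only part of what the source reports. "The series", "measured", "known", "first", "only" and "open" are said of these compounds alone.

Compound 1 `O=C(Nc1nc2ccc(Cl)cc2s1)c1cc(-c2ccc(F)cc2)n2nc(-c3ccccc3)cc2n1`: 17600 nM
Compound 2 `COc1ccc(-c2cc(C(=O)Nc3nc4ccc(Cl)cc4s3)nc3cc(-c4ccccc4)nn23)cc1OC`: 9330 nM

In a functional assay on DU-145 cells (Homo sapiens) for cytotoxicity, read by MTT assay, with a stated time of 48 h (on this read-out lower numbers stand for stronger inhibition and higher numbers for weaker inhibition), compound 2 gives 9330 nM, the lower of the two numbers measured, while compound 1 gives 17600 nM. Within the data shown here, the single measured step, a 1.9-fold lower number from compound 1 to compound 2 (0.28 log units; within the scatter), changed a different part of the molecule and does not speak to the present change. Compound 3 `COc1ccc(-c2cc(C(=O)Nc3nc4cc(C)c(C)cc4s3)nc3cc(-c4ccccc4)nn23)cc1OC` differs from compound 2 by 5,6-dimethyl-1,3-benzothiazol-2-yl in place of 6-chloro-1,3-benzothiazol-2-yl on an amide-type nitrogen. Among the measured compounds shown here, no measured step bears on this change, so no movement beyond the scatter is expected, with the step of a 1.0-fold higher number from compound 2 to compound 3 (0.01 log units; within the scatter) reflecting that. Compound 3 is expected to give about 9500 nM, within 3000 nM to 30000 nM.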

Compound 3, half-maximal inhibitory concentration: 6910 nM
Beside the measured number, compound 3's estimate is 1.4-fold (0.14 log units) above it, within the range that was stated.
By their numbers in this assay, from the lowest: compounds 3, 2 and 1 (each within the scatter of the next, the first and the last beyond it).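

In this assay, the amide-type nitrogen carries its first tested change, 5,6-dimethyl-1,3-benzothiazol-2-yl in place of 6-chloro-1,3-benzothiazol-2-yl, giving a 1.4-fold lower number from compound 2 to compound 3 (0.13 log units; within the scatter). So this exchange of groups leaves the two compounds indistinguishable on this read-out, which the earlier pair, differing elsewhere, could not show. Nothing available accounts for this outcome.

As far as these compounds go, whether an amine or a carboxylic acid on the 1,3-benzothiazol-2-yl group would give a step beyond the scatter remains open. So does whether this exchange would read the same with 4-fluorophenyl on the core.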